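A few compounds are considered here, and "the series" means these few. Any claim that something is new, unique, unknown or untested is made for them only; others in the source may bear on it.

Compound 1 (`CC1=CC[C@H]2[C@H](CC[C@]2(C)O)C(C)(C)[C@@H]1CC[C@H]1[C@]2(C)CC[C@H](OC(=O)c3ccccc3)C(C)(C)O[C@H]2CC[C@@]1(C)O`), compound 2 (`CC1=CC[C@H]2[C@H](CC[C@]2(C)O)C(C)(C)[C@@H]1CC[C@H]1[C@]2(C)CC[C@H](OC(=O)c3ccncc3)C(C)(C)O[C@H]2CC[C@@]1(C)O`) and compound 3 (`CC1=CC[C@H]2[C@H](CC[C@]2(C)O)C(C)(C)[C@@H]1CC[C@H]1[C@]2(C)CC[C@H](OC(=O)c3ccc(Cl)c(Cl)c3)C(C)(C)O[C@H]2CC[C@@]1(C)O`) share one core and differ only in the aromatic group on a carbonyl carbon. In a functional assay on MCF7 cells (Homo sapiens) for antiproliferative activity, read by MTT assay, with a stated time of 72 h (a higher number here means a weaker inhibitor, a lower number a stronger inhibitor), compound 1 gives 21000 nM and compound 2 gives 25300 nM while compound 3 gives 11900 nM as its reading. Compound 3 stands within the scatter of compound 1 (a 1.8-fold lower number from compound 1 to compound 3 (0.25 log units; within the scatter)) and only modestly clear of compound 2 (a 2.1-fold lower number from compound 2 to compound 3 (0.33 log units; beyond the scatter)). Compound 4 (`CC1=CC[C@H]2[C@H](CC[C@]2(C)O)C(C)(C)[C@@H]1CC[C@H]1[C@]2(C)CC[C@H](OC(=O)c3ccc(C(F)(F)F)c(F)c3)C(C)(C)O[C@H]2CC[C@@]1(C)O`) keeps the core and changes that group (3-fluoro-4-(trifluoromethyl)phenyl in place of 3,4-dichlorophenyl on a carbonyl carbon) so that 3-fluoro-4-(trifluoromethyl)phenyl stands in place of 3,4-dichlorophenyl on a carbonyl carbon. All the measured exchanges at this place are small, including the remaining one (a 1.2-fold higher number from compound 1 to compound 2 (0.08 log units; within the scatter)), though none compares one halogenated ring with another. For compound 4 the expected step is (a 1.1-fold higher number from compound 3 to compound 4 (0.02 log units; within the scatter)) and so none beyond the scatter in either direction. In this assay compound 4 is estimated at 12500 nM with an expected range from 6500 nM up to 23000 nM as the likely span.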

Compound 4, half-maximal inhibitory concentration: > 50000 nM
Compound 4 gave a limit, no number; the forecaster's own chance of this, stated with the estimate: 5%; at least 4.0-fold (0.60 log units) between middle value and limit.
By their numbers in this assay, from the lowest: compounds 3, 1 and 2 (each within the scatter of the next, the first and the last beyond it). At a limit, above all of these: compound 4.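

Compound 4's reading is a limit and not a number: the limit of > 50000 nM in this assay, at which 1 of the 4 values shown sits.

Going by these compounds alone, putting 3-fluoro-4-(trifluoromethyl)phenyl in place of 3,4-dichlorophenyl on a carbonyl carbon gives an at least 4.2-fold higher number from compound 3 to compound 4 (0.62 log units; beyond the scatter), larger than any step among the earlier compounds, so this place distinguishes between two halogenated rings. Against phenyl the change also clears the scatter, with an at least 2.3-fold higher number from compound 1 to compound 4 (0.37 log units; beyond the scatter), whereas against pyridin-4-yl the step is only a floor, with an at least 1.9-fold higher number from compound 2 to compound 4 (0.29 log units; that floor lies within the scatter).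

The compounds shown leave open how far compound 4 lies past its limit, and whether the shift follows the trifluoromethyl group, the fluorine or the two together. They also leave open what a ring carrying an amine or a carboxylic acid would give at this place.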